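This account rests on a few compounds, and the source may have more. Where it says the series, first, only, none or still open, it means among the compounds named here.

Working notes on the series. Two compounds have numbers in a functional assay on PC-3 cells (Homo sapiens) for inhibition, read by MTT assay, with a stated time of 72 h; on this read-out lower numbers stand for stronger inhibition and higher numbers for weaker inhibition. Compound 1 `CCSc1nc(Nc2cccc(OC)c2)c2ccncc2n1` gives 7150 nM in this assay. Going by the values given here, compound 2 `COc1cccc(Nc2nc(SCC3CC3)nc3cnccc23)c1` gives 14800 nM in this assay, the higher of the two numbers; its only neighbour is compound 1, and the gap between them is beyond the scatter. Among the compounds with values here, the single measured step, a 2.1-fold higher number from compound 1 to compound 2 (0.32 log units; beyond the scatter), put cyclopropyl in place of methyl on a saturated chain carbon bound to a sulfur.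

Compound 3 `COc1cccc(Nc2nc(SCC3CCCCC3)nc3cnccc23)c1` is not yet measured. It differs from compound 2 by cyclohexyl in place of cyclopropyl on a saturated chain carbon bound to a sulfur, the same place as the measured step, the ring growing from three to six carbons. Within the data shown here, the only step that bears on it is a 2.1-fold higher number from compound 1 to compound 2 (0.32 log units; beyond the scatter), a modest rise in the number when the group at this place was first enlarged. With one step as the whole basis, a further modest rise rather than a fall is expected for compound 3, because compound 2 already stands above compound 1 by a 2.1-fold higher number from compound 1 to compound 2 (0.32 log units; beyond the scatter). The expected step for compound 3 is a 1.7-fold higher number from compound 2 to compound 3 (0.23 log units; within the scatter). Compound 3 is therefore estimated at 25000 nM in this assay, with a range from 8000 nM to 70000 nM.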

Compound 3, half-maximal inhibitory concentration: 27500 nM
The estimate for compound 3 lay 1.1-fold (0.04 log units) below the measured number; the range from low to high includes it.
By their numbers in this assay, from the lowest: compound 1; then compounds 2 and 3 (each within the scatter of the next).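

In this assay, cyclohexyl in place of cyclopropyl on a saturated chain carbon bound to a sulfur gives a 1.9-fold higher number from compound 2 to compound 3 (0.27 log units; within the scatter), so a ring of six carbons cannot be told apart from a ring of three at this place, something a single ring could not show. Measured against methyl at the same place, cyclohexyl gives a 3.8-fold higher number from compound 1 to compound 3 (0.59 log units; beyond the scatter), so both ring-bearing compounds now stand on the weaker side of compound 1, and none of the three goes against this. No measurement here bears on the reason for these numbers.

Going by these compounds, what a phenyl ring, a longer straight chain, or a chain ending in an amine or a carboxylic acid would give at this place remains open, as does whether any group there can bring the number below that of compound 1. Also open, on these data alone, is whether the small gap between the two rings and the larger gap from methyl would hold on other cell lines or with a different group elsewhere on the shared core.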